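Swapping the five-membered ring of compound 2

This account rests on a few compounds, and the source may have more. Where it says the series, first, only, none or still open, it means among the compounds named here.

The measured compounds are:
compound 1, `Cn1nc2c(=O)n(CC3(O)CCN(Cc4ccc(-c5ccco5)cc4Cl)CC3)cnc2c1-c1ccc(C(F)(F)F)cc1`, with 530 nM;
compound 2, `Cn1nc2c(=O)n(CC3(O)CCN(Cc4ccc(-c5n[nH]c(=O)o5)cc4Cl)CC3)cnc2c1-c1ccc(CN)cc1`, with 171 nM;
compound 3, `Cn1nc2c(=O)n(CC3(O)CCN(Cc4ccc(-c5ccco5)cc4Cl)CC3)cnc2c1-c1ccc(CNC(=O)C(F)(F)F)cc1`, with 2060 nM.

All three were tested in an assay on isolated protein for inhibition of ubiquitin carboxyl-terminal hydrolase 7 (Homo sapiens), with stated times of 30 min and 2 h; a lower number here means a stronger inhibitor, a higher number a weaker inhibitor. Compound 2 stands lowest of the three numbers; compound 1 is nearest, with a higher number beyond the scatter, and compound 3 is furthest. Among the compounds with values here, the only measured single-point step is a 3.9-fold higher number from compound 1 to compound 3 (0.59 log units; beyond the scatter), and it concerns the other aromatic ring, not the position now in question. Compound 4 `Cn1nc2c(=O)n(CC3(O)CCN(Cc4ccc(-c5ccco5)cc4Cl)CC3)cnc2c1-c1ccc(CN)cc1` has not yet been measured in this assay. It differs from compound 2 in a group of 5 heavy atoms (4 carbon, 1 oxygen; one five-membered aromatic ring with 1 hetero atom) in place of a group of 6 heavy atoms (2 carbon, 2 nitrogen, 2 oxygen; one five-membered aromatic ring with 3 hetero atoms), on an aromatic carbon. Within the data shown here, no measured pair isolates this exchange: compound 1 and compound 2 differ in two places, so their values show only that the furan-bearing compound 1 sits higher than compound 2 without telling which change carries that difference. The step from compound 1 to compound 3 shows that a change on the far ring moves the number modestly, which gives no direct guide here. The expectation for compound 4 is therefore a modest step upward from compound 2, a 1.8-fold higher number from compound 2 to compound 4 (0.24 log units; within the scatter), with wide uncertainty. Compound 4 is estimated at 300 nM, expected between 110 nM and 850 nM.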

Compound 4, half-maximal inhibitory concentration: 18.1 nM
For compound 4 the middle estimate is 17-fold (1.22 log units) above the measured one; the whole stated range lies above it.
By their numbers in this assay, from the lowest: compound 4; then compound 2; then compound 1; then compound 3.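

In this assay the ring exchange can now be read on its own, with aminomethyl held on the far ring: a 9.4-fold lower number from compound 2 to compound 4 (0.98 log units; beyond the scatter), with furan-2-yl entering on the aromatic carbon meta to the chloro group and para to a large group, and the step lies beyond the scatter. Compound 4 also opens the far ring to comparison with furan-2-yl held fixed, as a 29-fold lower number from compound 1 to compound 4 (1.47 log units; beyond the scatter) follows aminomethyl replacing trifluoromethyl, while a 110-fold lower number from compound 3 to compound 4 (2.06 log units; beyond the scatter) follows hydrogen replacing (trifluoromethyl)carbonyl on the amine nitrogen, so both large steps favour the aminomethyl compound and the far-ring change proves at least as influential as the exchange at the ring position in question. Nothing available explains why either of these exchanges moves the number as it does. The compounds shown leave open whether the gain belongs to furan-2-yl in particular, since no thiophene, pyrrole, oxazole or phenyl stands at this position. They also leave open how much of the far-ring effect depends on the aminomethyl chain itself, as no aminoethyl, methylaminomethyl or hydroxymethyl group appears there, and whether the ring exchange would give the same step with trifluoromethyl on that ring.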